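The compounds below may be only part of what the source reports. "The series", "measured", "known", "first", "only" and "open" are said of these compounds alone.

Going by the values given here, compound 1 `CCCCCC(=O)Nc1ccc(S(=O)(=O)Oc2ccccc2C(C)C)cc1` is one of only two compounds measured in a functional assay on MCF7 cells (Homo sapiens) for antiproliferative activity, read by sulforhodamine B assay, with a stated time of 48 h; on this read-out higher numbers stand for weaker inhibition and lower numbers for stronger inhibition. In this assay compound 1 gives 5300 nM, and compound 2 `CCCCCC(=O)Nc1ccc(S(=O)(=O)Oc2ccccc2I)cc1` gives 10000 nM; the step of a 1.9-fold higher number from compound 1 to compound 2 (0.28 log units; within the scatter) arises from iodo in place of isopropyl on an aromatic carbon, and leaves the two within the scatter. Compound 3 `CCCCCNC(=O)Nc1ccc(S(=O)(=O)Oc2ccccc2C(C)C)cc1` differs from compound 1 elsewhere: pentylamino in place of pentyl on a carbonyl carbon. Among the compounds with values here, no measured step touches the carbonyl side of the molecule, so the single measured pair gives no direction, and no step beyond the scatter is expected. Compound 3 is estimated at 5300 nM, with a range from 2000 nM to 14000 nM. The expected step is no change at the digits printed from compound 1 to compound 3 (within the scatter).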

Compound 3, half-maximal inhibitory concentration: 4000 nM
Compound 3: middle estimate off by 1.3-fold (0.12 log units), on the high side; the range from low to high includes it.
By their numbers in this assay, from the lowest: compounds 3, 1 and 2 (each within the scatter of the next, the first and the last beyond it).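

In this assay, going by these compounds alone, the change reads as a 1.3-fold lower number from compound 1 to compound 3 (0.12 log units; within the scatter), the first measured step on the carbonyl side of the molecule. Pentylamino on the carbonyl carbon, with its extra nitrogen and hydrogen-bond donor, therefore gives a result that cannot be told apart from that of pentyl. No outside evidence bears on this result.

Still open, as far as these compounds go, is how a longer chain such as octyl, or a phenyl ring, would fare on this carbonyl carbon. Also open, from the compounds shown here alone, is whether pentylamino gives the same result alongside iodo in place of isopropyl.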